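A few compounds are considered here, and "the series" means these few. Any claim that something is new, unique, unknown or untested is made for them only; others in the source may bear on it.

Compound 1 `C=C1CCCC(C)(C)C1(O)CC/C(C)=C/CC[C@]1(C)CC[C@@H]([C@@H](C)C(=O)OC)OO1`: > 17500 nM
Compound 2 `C=C1CCCC(C)(C)C1CC[C@]1(C)CC[C@H]([C@@H](C)C(=O)OC)OO1`: 4540 nM
Compound 3 `C=C1CCCC(C)(C)C1CC[C@@]1(C)CC[C@H]([C@@H](C)C(=O)O)OO1`: 8310 nM

The three compounds were tested in a functional assay on COLO 205 cells (Homo sapiens) for inhibition; a higher number here means a weaker inhibitor of growth, a lower number a stronger inhibitor of growth. Compound 1 reaches only a limit of the assay, > 17500 nM, and no number is known for it. Compound 2 gives 4540 nM, and compound 3 gives 8310 nM. Of the two numbers, compound 3 holds the higher one, but its nearest neighbour is compound 2 and the gap between them lies within the usual scatter, so the two cannot be ranked in this assay.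

Compound 4 `C=C1CCCC(C)(C)C1CC[C@]1(C)CC[C@@H]([C@@H](C)C(=O)O)OO1` has not yet been measured. It differs from compound 3 as follows: the two compounds have the same atoms and bonds; at least one stereo element is drawn with a configuration in one of them and without one in the other: 2 of 4 stereo elements differ; a stereocentre at a saturated ring carbon is drawn S in compound 3 and R in compound 4; a stereocentre at a saturated ring carbon is drawn R in compound 3 and S in compound 4. Among the measured compounds shown here, no step between two measured compounds shows what such an inversion of two ring stereocentres does here, so no direction can be taken from the data. In this assay the expected step from compound 3 to compound 4 is a 1.1-fold lower number from compound 3 to compound 4 (0.04 log units; within the scatter), which is none beyond the scatter. Compound 4 is therefore estimated at 7500 nM, with a range from 2500 nM to 22000 nM.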

Compound 4, concentration for 50% growth inhibition: > 10000 nM
Compound 4 gave a limit, no number; the forecaster's own chance of this, stated with the estimate: 20%; at least 1.3-fold (0.12 log units) between middle value and limit.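

Inverting the two ring stereocentres gives the first step in this series that changes configuration alone, and in this assay it reads an at least 1.2-fold higher number from compound 3 to compound 4 (0.08 log units; that floor lies within the scatter). Compound 4 gives a limit and no number, so this step has a floor but no upper end, and that floor is set by a single value: the limit of > 10000 nM in this assay, at which 1 of the 4 values shown sits. The inversion therefore shows no sign of giving a lower number, but how much higher the true value of compound 4 lies cannot be read.

On these data alone, it remains open whether this inversion has a real effect on growth inhibition and whether it would act in the same way on a methyl ester. The compounds shown also do not tell how an amide in place of the carboxylic acid would behave under either configuration.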